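From hydroxy to (trifluoromethyl)sulfanyl on the shared core

A few compounds are considered here, and "the series" means these few. Any claim that something is new, unique, unknown or untested is made for them only; others in the source may bear on it.

In a physicochemical assay for solubility, at pH 7.4 (a lower number here means a less soluble compound, a higher number a more soluble compound), compound 3 `Cc1cc(NC(=O)Nc2ccc(O)cc2)c2ccccc2n1` gives 100 nM, level with compound 1 `Cc1cc(NC(=O)Nc2ccc(C(F)(F)F)cc2)c2ccccc2n1` at 100 nM. These two share the lowest number of the three, while compound 2 `Cc1cc(NC(=O)Nc2ccc(C(N)=O)cc2)c2ccccc2n1` reaches 900 nM. Compound 4 `Cc1cc(NC(=O)Nc2ccc(SC(F)(F)F)cc2)c2ccccc2n1` carries (trifluoromethyl)sulfanyl in place of hydroxy on an aromatic carbon. Two kinds of step bear on this. Hydroxy for trifluoromethyl gave no change at the digits printed from compound 1 to compound 3 (within the scatter), within the scatter, whereas carbamoyl stood apart, with modest steps of a 9.0-fold higher number from compound 1 to compound 2 (0.95 log units; beyond the scatter) and a 9.0-fold lower number from compound 2 to compound 3 (0.95 log units; beyond the scatter). Compound 4 has no carbamoyl and contains trifluoromethyl, like compound 1 at 100 nM, so no step beyond the scatter is expected in this assay. The expected change is a 1.4-fold lower number from compound 3 to compound 4 (0.15 log units; within the scatter). Compound 4 is estimated at 70 nM, within a range of 25 nM to 200 nM.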

Compound 4, solubility: 200 nM
The estimate for compound 4 lay 2.9-fold (0.46 log units) below the measured number; measured number inside the range.
By their numbers in this assay, from the lowest: compounds 1, 3 and 4 (each within the scatter of the next); then compound 2.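

In this assay, (trifluoromethyl)sulfanyl, which has no hydrogen-bond donor, stays within the scatter of both hydroxy, with a 2.0-fold higher number from compound 3 to compound 4 (0.30 log units; within the scatter), and trifluoromethyl, with a 2.0-fold higher number from compound 1 to compound 4 (0.30 log units; within the scatter). This position has now carried three groups that cannot be told apart here, while carbamoyl alone stands apart, with a 4.5-fold lower number from compound 2 to compound 4 (0.65 log units; beyond the scatter). No supporting measurement is available to explain this result. Going by these compounds, it remains open whether an amine or a carboxylic acid at this position would stand with carbamoyl or with the other three groups.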